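Two methoxy steps on a shared core

The source may report more compounds than this note shows. Statements on the series, on what has been measured and on what is new or still open speak of the compounds shown alone.

Measured so far in an assay on HepG2 cells for activation of nuclear factor erythroid 2-related factor 2 (Homo sapiens), read by a luciferase reporter, with a stated time of 5 h; on this read-out lower numbers stand for an effect already at smaller amounts and higher numbers for an effect only at larger amounts of compound:
compound 1, `Fc1cccc(/C=C/c2ccccc2)c1`, gives 3100 nM
compound 2, `COc1cccc(/C=C/c2cccc(F)c2)c1`, gives 2300 nM

Compound 2 carries the lower of the two numbers, but the step of a 1.3-fold lower number from compound 1 to compound 2 (0.13 log units; within the scatter) lies within the scatter, so compound 2 and compound 1 stand level on the data shown and no order between them is claimed.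

Compound 3, `COc1ccc(/C=C/c2cccc(F)c2)cc1OC`, remains to be measured. It differs from compound 2 by methoxy in place of hydrogen on an aromatic carbon. Within the data shown here, the single measured step that bears on this change is the methoxy-for-hydrogen exchange from compound 1 to compound 2, which stayed within the scatter. Among the measured compounds shown here, with only that step as a guide, the second methoxy exchange is expected to move this assay by little, if anything; neither direction is supported beyond the scatter, though a slight drift toward a lower number would follow the sign of the earlier step.

For compound 3 the expected value is 1800 nM, with a range from 700 nM to 4500 nM. That estimate corresponds to a step of a 1.3-fold lower number from compound 2 to compound 3 (0.11 log units; within the scatter), which is expected to remain within the scatter.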

Compound 3, half-maximal effective concentration: 9500 nM
Beside the measured number, compound 3's estimate is 5.3-fold (0.72 log units) below it; the whole stated range lies below it.
By their numbers in this assay, from the lowest: compounds 2 and 1 (each within the scatter of the next); then compound 3.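

In this assay the exchange of methoxy for hydrogen on an aromatic carbon now gives a step that can be read: a 4.1-fold higher number from compound 2 to compound 3 (0.62 log units; beyond the scatter), while the earlier exchange gave only a 1.3-fold lower number from compound 1 to compound 2 (0.13 log units; within the scatter). Among these compounds, the same named change therefore has no single size, and at this place, ortho to a methoxy group and para to a group of 9 heavy atoms, it produces the first step beyond the scatter, in the direction of a higher number, so the added methoxy is not tolerated here as the earlier exchange was. Nothing available explains this step.

It remains open whether the rise belongs to a methoxy at this place as such or depends on the methoxy already present, since no compound shown carries the new methoxy alone. Also open, from the compounds shown here alone, is how the number would respond to a different group at this place, such as a hydroxy group, an amine, a carboxylic acid or a longer alkoxy chain, and whether a smaller group such as fluorine would keep compound 2's level.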